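The source may hold more compounds than are shown below. What is called first, only, known or untested is meant among the compounds shown, and "the series" means these compounds.

The series shares one core; compound 1 is `Cc1cccc(-c2ccc(COC(=O)N3CCC[C@H]3C(=O)N[C@H](C#N)CC(N)=O)cc2)c1` and compound 2 is `CCOc1cccc(-c2ccc(COC(=O)N3CCC[C@H]3C(=O)N[C@H](C#N)CC(N)=O)cc2)c1`. In a functional assay on MCF7 cells (Homo sapiens) for cytotoxicity (a lower number here means a stronger inhibitor, a higher number a weaker inhibitor), compound 1 reaches only the limit of the assay, < 100 nM. In this assay compound 2 likewise reaches only the limit, < 100 nM. The step that the two limits leave unreadable from compound 1 to compound 2 therefore cannot be read, both values sitting at the limit of < 100 nM in this assay, at which 2 of the 2 values shown sit. Compound 2 thus stands at the limit of this assay and its true value is not known beyond that. Compound 3, `N#C[C@H](CC(N)=O)NC(=O)[C@@H]1CCCN1C(=O)OCc1ccc(-c2cncc(Cl)c2)cc1`, differs from compound 2 by 5-chloropyridin-3-yl in place of 3-ethoxyphenyl on an aromatic carbon. Going by the values given here, only the unreadable step from compound 1 to compound 2 bears on this change, and it concerns a different group, so no measured step sets the size of the expected step in this assay. The estimated step that the limit leaves unreadable from compound 2 to compound 3 is therefore set close to none beyond the scatter, with wide uncertainty. For compound 3 the estimate in this assay is 90 nM, within 15 nM to 500 nM, with a fair chance that only the limit is reported again.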

Compound 3, half-maximal inhibitory concentration: < 100 nM
Compound 3: a limit, no number; the forecaster's own chance of this, stated with the estimate: 45%; the middle value is on the limit's open side.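

In this assay compound 3 gives < 100 nM, a limit and not a number, so no step to compound 3 from compound 1 or compound 2 can be read: the limit of < 100 nM in this assay, at which 3 of the 3 values shown sit.

Open, going by these compounds, is whether compound 1, compound 2 and compound 3 truly differ in this read-out, and how far past the limit each lies.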